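One Stereocentre Changed on a Compound at the Limit

The source may report more compounds than this note shows. Statements on the series, on what has been measured and on what is new or still open speak of the compounds shown alone.

Compound 1 `C=C1CCC[C@H]2[C@](C)(CC[C@]3(C)CC[C@@H]([C@@H](C)C(=O)O)OO3)[C@@H](C)CC[C@]12C` and compound 2 `CC1=C(CC/C(C)=C/CC[C@@]2(C)CC[C@@H]([C@H](C)C(=O)O)OO2)C(C)(C)CCC1` differ in many places at once. In a functional assay on EKVX cells (Homo sapiens) for inhibition (on this read-out higher numbers stand for weaker inhibition of growth and lower numbers for stronger inhibition of growth), compound 1 gives 1090 nM. For compound 2 this assay reports only a limit, > 100000 nM. That value is the limit of > 100000 nM in this assay, at which 1 of the 2 values shown sits. Compound 3 `CC1=C(CC/C(C)=C/CC[C@@]2(C)CC[C@H]([C@H](C)C(=O)O)OO2)C(C)(C)CCC1` is one change away from compound 2: the two compounds have the same atoms and bonds and differ only in configuration as drawn: 1 of 4 stereo elements differ; a stereocentre at a saturated ring carbon is drawn S in compound 2 and R in compound 3. Among the compounds with values here, no measured pair isolates such a change, so the expected step from an at least 1.6-fold lower number from compound 2 to compound 3 (0.22 log units; that floor lies within the scatter) is small, most likely none beyond the scatter, with any movement possible in one direction only from a limit. Compound 3 is therefore estimated at 60000 nM, within a range from 10000 nM to 100000 nM.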

Compound 3, concentration for 50% growth inhibition: > 5000 nM
Compound 3: a limit, no number (the forecaster's own chance of this, stated with the estimate: 60%); the middle value lies beyond the limit too.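

In this assay, within the data shown here, compound 2 and compound 3 each give only a limit, so no step between them can be read. On these data alone, whether the changed stereocentre at the saturated ring carbon alters growth inhibition at all remains open.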